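Replacing the Amino-Methoxyphenyl Arm on the Shared Core

A few compounds are considered here, and "the series" means these few. Any claim that something is new, unique, unknown or untested is made for them only; others in the source may bear on it.

For the measured compounds named here, compound 1 `COc1ccc(-c2cc3nccc(-c4cc(OC)c(OC)c(OC)c4)n3n2)cc1N` is the one compound of the set that yields a number in a functional assay on A549 cells (Homo sapiens) for inhibition, read by CCK-8 assay, with a stated time of 48 h; a lower number here means a stronger inhibitor, a higher number a weaker inhibitor: compound 1 gives 138 nM. Compound 2 `COc1cc(-c2ccnc3c(-c4ccc(C)cc4)cnn23)cc(OC)c1OC`, with a different aromatic substituent on the shared core, gives in this assay > 10000 nM, which is a limit. Compound 3 `COc1ccc(-c2cc3nccc(-c4cc(OC)c(OC)c(OC)c4)n3n2)cc1[N+](=O)[O-]` differs from compound 1 by nitro in place of amino on an aromatic carbon. In this assay compound 3 gives > 10000 nM, again a limit. The step of an at least 72-fold higher number from compound 1 to compound 3 (1.86 log units; beyond the scatter) thus runs into (the limit of > 10000 nM in this assay, at which 2 of the 3 values shown sit).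

Compound 4 `COc1cc(-c2ccnc3cc(-c4ccc(C(C)(C)C)cc4)nn23)cc(OC)c1OC` has not yet been measured in this assay. It differs from compound 1 by 4-(tert-butyl)phenyl in place of 3-amino-4-methoxyphenyl on an aromatic carbon. Going by the values given here, the one measured step that bears on this change is the step from compound 1 to compound 3, where replacing the amino group alone carried the value to the limit. Compound 4 gives up both the amino group and the methoxy group of that arm, so a large weakening is expected, most probably reaching the limit once more. For compound 4 the expected step is a 58-fold higher number from compound 1 to compound 4 (1.76 log units; beyond the scatter). Compound 4 is therefore estimated at 8000 nM, within a range from 1500 nM to 30000 nM.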

Compound 4, half-maximal inhibitory concentration: > 10000 nM
Compound 4: only a limit was reported; the forecaster's own chance of this, stated with the estimate: 55%; middle value at least 1.2-fold (0.09 log units) away from the limit.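

In this assay, exchanging the whole arm on the aromatic carbon of the five-membered ring gives an at least 72-fold higher number from compound 1 to compound 4 (1.86 log units; beyond the scatter), a step that ends at a limit and not at a number. For the compounds shown here, the earlier step changed a single group and kept the methoxy group on the arm, whereas this one shows that a 4-(tert-butyl)phenyl arm, made of carbon only and with no hydrogen-bond donors or acceptors, also yields no number at this place, leaving compound 1 at 138 nM as the only compound with one. The true size of the step stays unknown, and compound 2, compound 3 and compound 4 cannot be ordered among themselves: the limit of > 10000 nM in this assay, at which 3 of the 4 values shown sit.

The compounds shown leave open whether the amino group alone accounts for the value of compound 1 or whether it needs the methoxy group on the same ring. A 3-aminophenyl arm without the methoxy group, a 4-methoxyphenyl arm without the amino group, or a hydroxyl or methylamino group in place of the amino group would each separate these parts of the arm.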